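The source may report more compounds than this note shows. Statements on the series, on what has been measured and on what is new or still open speak of the compounds shown alone.

Measured in an ADME assay on MDBK cells (Bos taurus) for cytotoxicity; a lower number here means that less compound is tolerated, a higher number that more compound is tolerated:
- compound 1 `Ic1ccc(Cn2ccc3nc(-c4ccccc4)nc-3c2)cc1`: 22000 nM
- compound 2 `CC(C)CCn1ccc2nc(-c3ccccc3)nc-2c1`: > 100000 nM (a limit of the assay)

Compound 2 stands at the limit of > 100000 nM in this assay, at which 1 of the 2 values shown sits, so no number is available for it, only a limit.

Compound 3 `C(=C/c1ccccc1)\Cn1ccc2nc(-c3ccccc3)nc-2c1` carries 2-phenylethenyl in place of isobutyl on a saturated chain carbon bound to an aromatic nitrogen.

For the measured compounds named here, one measured step bears on this change: an at least 4.5-fold higher number from compound 1 to compound 2 (0.65 log units; beyond the scatter). That step lies beyond the scatter and removes an aromatic ring from the substituent, whereas the change to compound 3 puts one back. A step in the opposite direction, towards a lower number in this assay, is therefore expected, on the reasoning that compound 3 resembles compound 1 in this respect. Compound 3 has no iodine, however, and a single step is a thin basis, so a result that also ends at the limit remains possible. The expected size is modest: an at least 2.2-fold lower number from compound 2 to compound 3 (0.34 log units; beyond the scatter). Compound 3 is estimated at 45000 nM, with an expected range of 15000 nM to 100000 nM.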

Compound 3, half-maximal cytotoxic concentration: 78000 nM
For compound 3 the middle estimate is 1.7-fold (0.24 log units) below the measured one, within the range that was stated.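

In this assay, the substituent on a saturated chain carbon bound to an aromatic nitrogen can carry an aromatic ring without reaching the level of compound 1: 2-phenylethenyl in place of 4-iodophenyl gives a 3.5-fold higher number from compound 1 to compound 3 (0.55 log units; beyond the scatter). The comparison with the isobutyl group is less firm: 2-phenylethenyl in place of isobutyl gives an at least 1.2-fold lower number from compound 2 to compound 3 (0.10 log units; that floor lies within the scatter), and with that floor inside the scatter, this step alone does not establish a real fall in the number. Compound 2 has only a limit of the assay, not a number, which leaves the true size of this step undefined: the limit of > 100000 nM in this assay, at which 1 of the 3 values shown sits.

The 4-iodophenyl and 2-phenylethenyl groups differ in more than one feature, and the compounds shown do not separate the contribution of the iodine from that of the double bond. An unsubstituted benzyl group at this position would address that question directly, while an amine or a carboxylic acid on the chain would show whether the number in this assay moves with groups of a different kind from the carbon-only substituents seen so far.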